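Succinimide amide series: trifluoromethyl in place of fluoro

This account rests on a few compounds, and the source may have more. Where it says the series, first, only, none or still open, it means among the compounds named here.

Measured so far:
- compound 1, `CC(C(=O)NCc1ccc(C(F)(F)F)cc1)N1C(=O)CCC1=O`: 54.5 mg/kg
- compound 2, `CCC(C(=O)NCc1ccc(F)cc1)N1C(=O)CCC1=O`: 83.4 mg/kg

In a functional assay on the whole organism (strain Albino Swiss CD1) with Mus musculus as the target (a higher number here means that more compound is needed for the effect, a lower number that less compound is needed), compound 2 gives 83.4 mg/kg, the higher of the two numbers, while compound 1 gives 54.5 mg/kg. The gap between compound 2 and compound 1 lies within the usual scatter of this assay, so the two values cannot be told apart.

Compound 3, `CCC(C(=O)NCc1ccc(C(F)(F)F)cc1)N1C(=O)CCC1=O`, is not yet measured in this assay. It differs from compound 2 by trifluoromethyl in place of fluoro on an aromatic carbon. For the measured compounds named here, the same trifluoromethyl group is present in compound 1, which carries a shorter chain at the other site; no step between measured compounds isolates this change, so its size is not known from the data.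

Given that compound 1 gives 54.5 mg/kg with the same aromatic group, compound 3 is expected to fall near that value. The step from compound 2 to compound 3 is estimated at a 1.4-fold lower number from compound 2 to compound 3 (0.14 log units; within the scatter), toward a lower number but not beyond the scatter. For compound 3 the expected value in this assay is 60 mg/kg, with a range from 28 mg/kg to 130 mg/kg.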

Compound 3, dose for half-maximal effect: 80.4 mg/kg
Compound 3: middle estimate off by 1.3-fold (0.13 log units), on the low side; the measured number falls inside the stated range.
By their numbers in this assay, from the lowest: compounds 1, 3 and 2 (each within the scatter of the next).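

In this assay the exchange of fluoro for trifluoromethyl on an aromatic carbon, para to a large group, can now be read in isolation (a 1.0-fold lower number from compound 2 to compound 3 (0.02 log units; within the scatter)), and the entering group of 4 heavy atoms against 1 gives no difference that can be told from the scatter. For the compounds shown here, the chain site can also be read for the first time: methyl in place of hydrogen on a saturated chain carbon, two bonds along the chain from an amide-type nitrogen in a ring and a carbonyl carbon, gives a step that also stays within the scatter (a 1.5-fold higher number from compound 1 to compound 3 (0.17 log units; within the scatter)). Neither single change therefore separates any of the compounds connected by these steps, and no supporting measurement bears on the reason.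

Going by these compounds, whether the aromatic position responds at all to a different kind of group remains open, for example hydrogen, methoxy, nitrile or an amine in place of trifluoromethyl. At the chain site, a longer chain such as propyl, or a branched chain such as isopropyl, would show whether the reading holds beyond methyl.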